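Swapping fluoro for hydrogen in compound 2

The compounds below may be only part of what the source reports. "The series", "measured", "known", "first", "only" and "open" are said of these compounds alone.

Values in an ADME assay on CEM-SS cells (Homo sapiens) for cytotoxicity, read by XTT assay; a higher number here means that more compound is tolerated, a lower number that less compound is tolerated:
- compound 1 `N#Cc1cccc(Cn2ccc3cc(C(=O)NO)ncc32)c1`: > 10000 nM (a limit)
- compound 2 `NC(=O)c1cc(Cn2ccc3cc(C(=O)NO)ncc32)ccc1F`: > 10000 nM (a limit)

Neither entry is a true number, and compound 2 stands at the limit of > 10000 nM in this assay, at which 2 of the 2 values shown sit. Compound 3 `NC(=O)c1cccc(Cn2ccc3cc(C(=O)NO)ncc32)c1` differs from compound 2 by one change (hydrogen in place of fluoro on an aromatic carbon): hydrogen in place of fluoro on an aromatic carbon. For the measured compounds named here, no measured step between compounds is available to gauge this change in this assay. An estimated step (a step that the limit leaves unreadable from compound 2 to compound 3) no larger than the usual scatter is expected, with neither direction favoured. For compound 3 the expected value is 14000 nM (estimated range 6000 nM to 40000 nM).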

Compound 3, half-maximal cytotoxic concentration: > 10000 nM
Compound 3 gave a limit, no number; the forecaster's own chance of this, stated with the estimate: 85%; the middle value lies beyond the limit too.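

No step can be read from compound 2 to compound 3 or from compound 1 to compound 3 in this assay, as all three compounds give only a limit: the limit of > 10000 nM in this assay, at which 3 of the 3 values shown sit. The compounds shown leave open how much of any of them is actually tolerated, and whether swapping fluoro for hydrogen or cyano for carbamoyl changes that.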